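Working notes: pyridyl ring position and paw edema inhibition

The source may hold more compounds than are shown below. What is called first, only, known or untested is meant among the compounds shown, and "the series" means these compounds.

Measured so far:
compound 1 `CNc1ncccc1C(=O)N/N=C/c1ccccc1`: 14.8%
compound 2 `CNc1ncccc1C(=O)N/N=C/c1cccnc1`: 13.8%

In a functional assay on the whole organism (strain Wistar) for inhibition, with Rattus norvegicus as the target, read by paw edema, with a stated time of 4 h, at a dose of 10 mg/kg by the intraperitoneal route (on this read-out lower numbers stand for less inhibition and higher numbers for more inhibition at the one dose given (going by the name of the read-out)), compound 1 gives 14.8% and compound 2 gives 13.8%. Within the data shown here, the single measured step, a number 1 percentage points lower from compound 1 to compound 2 (within the scatter), leaves the read-out essentially unchanged. Compound 2 stands lowest of the two numbers, yet its nearest neighbour lies within the scatter, so no order between them can be read. Compound 3 `CNc1ncccc1C(=O)N/N=C/c1ccncc1` is not yet measured; it differs from compound 2 by pyridin-4-yl in place of pyridin-3-yl on a carbon with a double bond to nitrogen. Among the measured compounds shown here, no measured step exchanges one pyridyl for another, so the one step within the scatter is the only guide, and nothing beyond the scatter is expected. For compound 3 in this assay a value of 14% is estimated, between 5% and 24%. The expected step is a number 0.2 percentage points higher from compound 2 to compound 3 (within the scatter), none beyond the scatter.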

Compound 3, a percentage reported as inhibition, in the whole organism at one dose (the size of the read-out at that dose, not a potency): 15.5%
Beside the measured number, compound 3's estimate is 1.5 percentage points below it; the range from low to high includes it.
By their numbers in this assay, from the lowest: compounds 2, 1 and 3 (each within the scatter of the next).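

In this assay, the exchange of one pyridyl for another on a carbon with a double bond to nitrogen gives a number 1.7 percentage points higher from compound 2 to compound 3 (within the scatter), and pyridin-4-yl in place of phenyl gives a number 0.7 percentage points higher from compound 1 to compound 3 (within the scatter). Moving the ring nitrogen within the pyridyl group therefore has no readable effect here, and phenyl, pyridin-3-yl and pyridin-4-yl cannot be put in any order. No supporting data bear on this flat result.

Open, as far as these compounds go, is whether any group at this place moves the read-out beyond the scatter, such as pyridin-2-yl or a phenyl ring carrying a carboxylic acid.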